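A few compounds are considered here, and "the series" means these few. Any claim that something is new, unique, unknown or untested is made for them only; others in the source may bear on it.

Compound 1 `CC1=CC[C@H](C(C)C)c2cc(C)c(OC(=O)c3ccc(C)cc3)cc21` gives 65% in a functional assay on MCF7 cells (Homo sapiens) for antiproliferative activity, read by sulforhodamine B assay, with a stated time of 48 h, tested at 50 uM (a lower number here means less inhibition, a higher number more inhibition at the concentration tested (going by the name of the read-out)), the lower of the two measured values. Going by the values given here, compound 2 `COc1ccc(C(=O)Oc2cc3c(C)ccc(C(C)C)c3cc2C)cc1` gives 93.4% in this assay, a higher number, though the two structures differ in more than one place and no single step joins them. Compound 3 `COc1ccc(C(=O)Oc2cc3c(cc2C)[C@@H](C(C)C)CC=C3C)cc1` differs from compound 1 as methoxy in place of methyl on an aromatic carbon. Among the compounds with values here, no measured pair isolates this change, so the step from compound 1 to compound 3 is expected to be modest, a number 11 percentage points higher from compound 1 to compound 3 (beyond the scatter), leaning upward but possibly not beyond the scatter. Compound 3 is therefore expected to give 76%, within 55% to 94%.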

Compound 3, a percentage reported as inhibition, at one concentration (the size of the read-out at that concentration, not a potency): 80.1%
Compound 3: the middle estimate sits 4.1 percentage points below what was measured, within the range that was stated.
By their numbers in this assay, from the lowest: compound 1; then compound 3; then compound 2.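

Replacing methyl with methoxy, as 4-methylphenyl to 4-methoxyphenyl with the rest of the core unchanged, gives a number 15.1 percentage points higher from compound 1 to compound 3 (beyond the scatter) in this assay. This is the first single-place step shown, and it establishes that the read-out responds to a change at this aromatic carbon, para to a large group. Nothing measured here accounts for the rise.

On these data alone, whether an amine, a carboxylic acid or a longer chain such as ethoxy at this position would raise or lower the number remains open. So does whether methoxy in place of methyl would produce a similar step on the core of compound 2.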